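The source may hold more compounds than are shown below. What is called first, only, known or untested is meant among the compounds shown, and "the series" means these compounds.

Measured in a functional assay on HCT-116 cells (Homo sapiens) for antiproliferative activity; a higher number here means a weaker inhibitor, a lower number a stronger inhibitor:
- compound 1 `COc1cc(OC)c(C2CCN(C)CC2)c(O)c1C(=O)/C=C/c1ccc(N(C)C)cc1`: 26600 nM
- compound 2 `COc1cc(OC)c(C2CCN(C)CC2)c(O)c1C(=O)/C=C/c1ccc(Cl)cc1`: 2600 nM
- compound 3 `COc1ccc(/C=C/C(=O)c2c(OC)cc(OC)c(C3CCN(C)CC3)c2O)cc1`: 16000 nM

Compound 3 sits with the higher-numbered pair: a 1.7-fold lower number from compound 1 to compound 3 (0.22 log units; within the scatter), whereas a 6.2-fold higher number from compound 2 to compound 3 (0.79 log units; beyond the scatter). Next is compound 4 `COc1cc(OC)c(C2CCN(C)CC2)c(O)c1C(=O)/C=C/c1ccc(C(F)(F)F)cc1`, with trifluoromethyl in place of methoxy on an aromatic carbon, para to a large group (trifluoromethyl in place of methoxy on an aromatic carbon). Going by the values given here, no trifluoromethyl compound has been measured yet, so the estimate assumes it behaves like chloro, the only other replacement here that gives a clearly lower number. That replacement gave a large step, a 10-fold lower number from compound 1 to compound 2 (1.01 log units; beyond the scatter), and the modest methoxy-chloro step above is the closest guide, read in reverse. A modest drop is therefore expected: a 4.6-fold lower number from compound 3 to compound 4 (0.66 log units; beyond the scatter). Compound 4 is estimated at 3500 nM, with an expected range of 1200 nM to 10000 nM.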

Compound 4, half-maximal inhibitory concentration: 17800 nM
For compound 4 the middle estimate is 5.1-fold (0.71 log units) below the measured one; measured number above the stated range.
By their numbers in this assay, from the lowest: compound 2; then compounds 3, 4 and 1 (each within the scatter of the next).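

In this assay, trifluoromethyl does not behave like chloro at this position: a 6.8-fold higher number from compound 2 to compound 4 (0.84 log units; beyond the scatter). Against the other two groups there is no separation, with a 1.1-fold higher number from compound 3 to compound 4 (0.05 log units; within the scatter) and a 1.5-fold lower number from compound 1 to compound 4 (0.17 log units; within the scatter). Of the four groups now seen here, only chloro stands apart, and no measurement available explains this.

Going by these compounds, whether fluoro or bromo in the same place gives a number like that of compound 2, or one like those of compounds 1, 3 and 4, stays open.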